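The source may report more compounds than this note shows. Statements on the series, on what has been measured and on what is new or still open speak of the compounds shown alone.

Working notes on the series. Of the compounds shown here, three have been measured so far in an assay on lysate for inhibition of 6-phosphofructo-2-kinase/fructose-2,6-bisphosphatase 3 (Homo sapiens), with stated times of 0.5 min and 45 min; a lower number here means a stronger inhibitor, a higher number a weaker inhibitor. Compound 1 `Cn1ccc2ccc(-c3cc(Nc4cnccc4C(=O)NCc4cncnc4)cc4nccnc34)cc21` gives 49500 nM, compound 2 `CC(=O)N1CCC(NC(=O)c2ccncc2Nc2cc(-c3ccc4ccn(C)c4c3)c3nccnc3c2)CC1` gives 31300 nM, and compound 3 `Cn1ccc2ccc(-c3cc(Nc4cnccc4C(=O)NC4CCNC(=O)C4)cc4nccnc34)cc21` gives 56500 nM. Compound 3 carries the highest of the three numbers, but the steps of a 1.1-fold higher number from compound 1 to compound 3 (0.06 log units; within the scatter) and a 1.8-fold higher number from compound 2 to compound 3 (0.26 log units; within the scatter) are both within the scatter, as is a 1.6-fold lower number from compound 1 to compound 2 (0.20 log units; within the scatter), so the three compounds sit together as weak inhibitors with no separation that can be read.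

Compound 4 `CN1CCC(NC(=O)c2ccncc2Nc2cc(-c3ccc4ccn(C)c4c3)c3nccnc3c2)CC1=O` differs from compound 3 in one place: methyl in place of hydrogen on an amide-type nitrogen in a ring. Within the data shown here, none of the measured steps tests this change; each of them exchanges the whole group on the amide-type nitrogen outside the ring, and all were within the scatter. Among the measured compounds shown here, with no step that bears on the change and all nearby steps small, no movement beyond the scatter is expected, so the step of no change at the digits printed from compound 3 to compound 4 (within the scatter) is expected to be flat. Compound 4 is therefore estimated at 56500 nM in this assay, with a range from 25000 nM to 130000 nM.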

Compound 4, half-maximal inhibitory concentration: 48800 nM
The estimate for compound 4 lay 1.2-fold (0.06 log units) above the measured number; the measured number falls inside the stated range.
By their numbers in this assay, from the lowest: compounds 2, 4, 1 and 3 (each within the scatter of the next).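

Methyl in place of hydrogen on the amide-type nitrogen in the ring is the first change tested at this position, and in this assay it gives a flat step (a 1.2-fold lower number from compound 3 to compound 4 (0.06 log units; within the scatter)), so the amide hydrogen of the 2-oxopiperidin-4-yl group can give way to methyl with no readable change. The new group also stays level with the other groups on the amide-type nitrogen outside the ring (a 1.6-fold higher number from compound 2 to compound 4 (0.19 log units; within the scatter); a 1.0-fold lower number from compound 1 to compound 4 (0.01 log units; within the scatter)), so 1-methyl-2-oxopiperidin-4-yl adds no separation to the series. Nothing available explains this flatness.

Going by these compounds, whether an ethyl or a benzyl on the ring nitrogen, or a primary amine or a carboxylic acid on the group outside the ring, would move the number beyond the scatter stays open. On these data alone, all four compounds share one core, so the effect of any change to that core also stays open.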